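Thiazolidinone series: cytotoxicity notes ahead of compound 4

The source may hold more compounds than are shown below. What is called first, only, known or untested is meant among the compounds shown, and "the series" means these compounds.

Measured so far, all in an ADME assay on Vero cells (Chlorocebus sabaeus) for cytotoxicity, read by neutral red uptake, tested at 49 ug/mL; a higher number here means a weaker effect of the compound at the concentration tested, a lower number a stronger effect:
- compound 1 `COc1ccc(C2SCC(=O)N2CCN2CCCCC2)cc1` gives 100%
- compound 2 `O=C1CSC(c2ccc(O)cc2)N1CCN1CCCCC1` gives 96%
- compound 3 `O=C1CSC(c2ccc([N+](=O)[O-])cc2)N1CCN1CCCCC1` gives 100%

On these numbers compound 2 stands close to both partners: the step of a number 4 percentage points lower from compound 1 to compound 2 (within the scatter) and the step of a number 4 percentage points higher from compound 2 to compound 3 (within the scatter) are each within the scatter, and the step of no change at the digits printed from compound 1 to compound 3 (within the scatter) likewise. None of the three changes on the aromatic ring moved this assay beyond its noise; every number sits at or near the full read-out.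

Compound 4 `O=C1CSC(c2cccc(F)c2)N1CCN1CCCCC1` is next. Relative to compound 2 the change is 3-fluorophenyl in place of 4-hydroxyphenyl on a saturated ring carbon. For the measured compounds named here, no measured step swaps the whole aromatic substituent in this way, so the only guidance is indirect: the three steps among compounds 1, 2 and 3 all altered the group on the same aromatic ring and all stayed within the scatter, as the steps of a number 4 percentage points lower from compound 1 to compound 2 (within the scatter) and a number 4 percentage points higher from compound 2 to compound 3 (within the scatter) show. On that basis the step of a number 2 percentage points higher from compound 2 to compound 4 (within the scatter) is expected to stay within the scatter as well, with no direction beyond noise. For compound 4 the estimate in this assay is 98%, with a range from 88% to 104%; an outcome outside that range is not predicted by the data in hand.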

Compound 4, a percentage reported as activity, at one concentration (the size of the read-out at that concentration, not a potency): 97%
For compound 4 the middle estimate is 1 percentage points above the measured one; the range from low to high includes it.
By their numbers in this assay, from the lowest: compounds 2, 4, 1 and 3 (each within the scatter of the next).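

In this assay, replacing 4-hydroxyphenyl with 3-fluorophenyl on the saturated ring carbon gives a number 1 percentage points higher from compound 2 to compound 4 (within the scatter). For the compounds shown here, this is the first step to exchange the whole aromatic substituent, bringing in fluorine and moving the ring substituent to a different ring place, while also losing the hydrogen-bond donor and acceptor counted on 4-hydroxyphenyl, and the combined change still leaves the read-out within the scatter. The four compounds therefore extend the flat picture from groups changed on one ring place to a different substitution place on the same aromatic ring, although no evidence bears on why the read-out stays flat.

As far as these compounds go, it remains open whether a carboxylic acid or a primary amine on the aromatic ring, or a naphthyl group in place of the substituted phenyl group, would leave this read-out where it stands. Also open, from the compounds shown here alone, are the effect of a longer chain on the ring nitrogen and whether any change to the shared core would produce a step beyond the scatter.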